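From acetoxymethyl to methoxymethyl: working notes

This account rests on a few compounds, and the source may have more. Where it says the series, first, only, none or still open, it means among the compounds named here.

Measured so far in a functional assay on ZR-75-1 cells (Homo sapiens) for cytotoxicity, read by sulforhodamine B assay, with a stated time of 3 days (a lower number here means that less compound is needed, a higher number that more compound is needed for the effect), for three compounds
compound 1 `CCOCc1c(C)coc1-c1ccc2c(c1OC)CCCC2(C)C` gives 19.8 uM
compound 2 `COC(=O)c1c(C)coc1-c1ccc2c(c1OC)CCCC2(C)C` gives 34.5 uM
compound 3 `COc1c(-c2occ(C)c2COC(C)=O)ccc2c1CCCC2(C)C` gives 15.5 uM

Compound 3 stands within the scatter of compound 1 and apart from compound 2, as a 2.2-fold lower number from compound 2 to compound 3 (0.35 log units; beyond the scatter) shows. Compound 4 (`COCc1c(C)coc1-c1ccc2c(c1OC)CCCC2(C)C`) differs from compound 3 by methyl in place of acetyl on an oxygen on a saturated carbon with methyl in place of acetyl on an oxygen on a saturated carbon. The step bearing most directly is a 1.3-fold lower number from compound 1 to compound 3 (0.11 log units; within the scatter) at that same oxygen, while a 1.7-fold higher number from compound 1 to compound 2 (0.24 log units; within the scatter) gives a second comparison. No step beyond the scatter is therefore expected, and the estimated step is a 1.2-fold higher number from compound 3 to compound 4 (0.09 log units; within the scatter) at this oxygen. For compound 4 the expected value is 19 uM with an estimated range of 10 uM to 36 uM around it.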

Compound 4, concentration for half-maximal effect: 14.3 uM
Compound 4: the middle estimate sits 1.3-fold (0.12 log units) above what was measured, within the range that was stated.
By their numbers in this assay, from the lowest: compounds 4, 3, 1 and 2 (each within the scatter of the next, the first and the last beyond it).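

In this assay, methyl in place of acetyl on this oxygen leaves no readable change (a 1.1-fold lower number from compound 3 to compound 4 (0.03 log units; within the scatter)), and the shorter ether likewise stays within the scatter of the ethoxymethyl compound (a 1.4-fold lower number from compound 1 to compound 4 (0.14 log units; within the scatter)). Methoxymethyl in place of methoxycarbonyl on the aromatic carbon gives a modest step beyond the scatter (a 2.4-fold lower number from compound 2 to compound 4 (0.38 log units; beyond the scatter)). Compounds 1, 3 and 4 thus cannot be told apart, while compound 2 lies apart from compounds 3 and 4 but stays within the scatter of compound 1. On these data alone, whether an amine or a carboxylic acid on this carbon would shift the number remains open. The data available here also give no cause for any of these steps.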